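Solubility Outlook for a Bulkier Amine Side Chain

The source may report more compounds than this note shows. Statements on the series, on what has been measured and on what is new or still open speak of the compounds shown alone.

Compound 1 `NCCOc1ccc([C@H]2CC[C@]3(CC2)OOC2(O3)C3CC4CC(C3)CC2C4)cc1` — > 100 ug/mL
Compound 2 `c1cc([C@H]2CC[C@]3(CC2)OOC2(O3)C3CC4CC(C3)CC2C4)ccc1OC1CCNCC1` — > 100 ug/mL

Compound 1 and compound 2 share a core and differ only in the group on the oxygen on the aromatic ring. In a physicochemical assay for solubility, read by nephelometry, measured as kinetic solubility, with a stated time of 30 min (a higher number here means a more soluble compound, a lower number a less soluble compound), compound 1 gives > 100 ug/mL, which is a limit of the assay rather than a number. In this assay compound 2 gives > 100 ug/mL, likewise a limit. The step that the two limits leave unreadable from compound 1 to compound 2 therefore cannot be read in size, because both values sit at the limit of > 100 ug/mL in this assay, at which 2 of the 2 values shown sit. Compound 2 thus stands at the limit, with no number of its own.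

Compound 3 `CC1(C)CC(O)(COc2ccc([C@H]3CC[C@]4(CC3)OOC3(O4)C4CC5CC(C4)CC3C5)cc2)CC(C)(C)N1` is not yet measured. It differs from compound 2 by (4-hydroxy-2,2,6,6-tetramethylpiperidin-4-yl)methyl in place of piperidin-4-yl on an oxygen on an aromatic ring. Among the measured compounds shown here, the only measured step, the one from compound 1 to compound 2, is unreadable, so no step gives a usable size for what this change should do in this assay. The estimate for compound 3 in this assay is 90 ug/mL, within 40 ug/mL to 150 ug/mL. This corresponds to an expected step of an at least 1.1-fold lower number from compound 2 to compound 3 (0.04 log units; that floor lies within the scatter).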

Compound 3, solubility: > 100 ug/mL
Compound 3 was reported as a limit; the forecaster's own chance of this, stated with the estimate: 45%; at least 1.1-fold (0.04 log units) between middle value and limit.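

In this assay compound 3 gives > 100 ug/mL, which is again a limit and not a number. No step among compound 1, compound 2 and compound 3 can be read in size, because all three values sit at one limit: the limit of > 100 ug/mL in this assay, at which 3 of the 3 values shown sit.

The compounds shown leave open how the solubility of these three compounds compares.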